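Replacing tert-butoxycarbonyl with acetyl on compound 3

The source may hold more compounds than are shown below. What is called first, only, known or untested is meant among the compounds shown, and "the series" means these compounds.

Measured in a functional assay on BXPC-3 cells (Homo sapiens) for inhibition, read by XTT assay, with a stated time of 72 h; a higher number here means a weaker inhibitor, a lower number a stronger inhibitor:
- Compound 1 `C=CCCCCCCOC[C@@H]1CCCN1C(=O)OC(C)(C)C`: 53300 nM
- Compound 2 `CC(C)(C)OC(=O)N1CCC[C@H]1COCCCCCC/C=C/c1ccc(-c2ccccc2)cc1`: > 100000 nM (a limit of the assay, not a number)
- Compound 3 `CC(C)(C)OC(=O)N1CCC[C@H]1COCCCCCC/C=C/c1ccc(Oc2ccccc2)cc1`: 63300 nM

Compound 3 gives 63300 nM and compound 1 gives 53300 nM, two values within the scatter of each other. The next compound is compound 4 `CC(=O)N1CCC[C@H]1COCCCCCC/C=C/c1ccc(Oc2ccccc2)cc1`. The structural change is methyl in place of tert-butoxy on a carbonyl carbon, or tert-butoxycarbonyl to acetyl.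

Within the data shown here, all three measured compounds carry tert-butoxycarbonyl, so no measured step covers this change. Among the measured compounds shown here, the only measured step is an at least 1.5-fold lower number from compound 2 to compound 3 (0.19 log units; that floor lies within the scatter), with phenoxy in place of phenyl on an aromatic carbon. That step concerns a different group and gives only weak guidance on size. No step beyond the scatter in this assay is therefore expected, and no direction can be favoured. The expected size is a 1.2-fold lower number from compound 3 to compound 4 (0.06 log units; within the scatter), with wide uncertainty. For compound 4 a reading at the limit of > 100000 nM in this assay, at which 1 of the 3 values shown sits, remains possible. Compound 4 is estimated at 55000 nM, with an expected range from 18000 nM to 100000 nM.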

Compound 4, half-maximal inhibitory concentration: 60000 nM
Compound 4: middle estimate off by 1.1-fold (0.04 log units), on the low side, and the stated range covers the measured number.
By their numbers in this assay, from the lowest: compounds 1, 4 and 3 (each within the scatter of the next). At a limit, above all of these: compound 2.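

In this assay, the position on the carbonyl carbon attached to the amide-type nitrogen in a ring tolerates tert-butoxycarbonyl to acetyl without a step beyond the scatter: a 1.1-fold lower number from compound 3 to compound 4 (0.02 log units; within the scatter). Among these compounds, this is the first measured change at this position, and it replaces tert-butoxy, with 5 heavy atoms, by methyl, with 1 heavy atom, while compound 4 still gives a number rather than a limit of the assay, so in this pair tert-butoxy is not needed for the reading seen with compound 3. No measured property shown here bears on why the two readings stay within the scatter of each other.

The compounds shown leave open whether a free amine at this nitrogen, a urea or a longer acyl chain on the carbonyl carbon would move the number beyond the scatter. As far as these compounds go, it also remains open whether tert-butoxycarbonyl to acetyl reads the same on compound 1 or compound 2, which carry other groups at the far end of the chain.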